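The source may hold more compounds than are shown below. What is called first, only, known or untested is meant among the compounds shown, and "the series" means these compounds.

Measured so far in a functional assay on DU-145 cells (Homo sapiens) for inhibition, read by trypan blue exclusion, with a stated time of 96 h; a lower number here means a stronger inhibitor of growth, a higher number a weaker inhibitor of growth:
compound 1, `O=C(/C(=C\c1ccc(Cl)cc1Cl)Sc1ccc(Br)cc1)c1ccc(Br)cc1`: 1000 nM
compound 2, `COc1cc(/C=C(/Sc2ccc(Br)cc2)C(=O)c2ccc(Br)cc2)ccc1O`: 1000 nM
compound 3, `Nc1c(Br)cc(Br)cc1/C=C(/Sc1ccc(Br)cc1)C(=O)c1ccc(Br)cc1`: > 100000 nM

Compound 3 stands apart from the other two. Its result is a limit of the assay rather than a number, (the limit of > 100000 nM in this assay, at which 1 of the 3 values shown sits), and it sits at that limit alone among the three. Compound 1 and compound 2 sit together, since no change at the digits printed from compound 1 to compound 2 (within the scatter).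

Compound 4, `COc1cc(/C=C(/Sc2ccc(Br)cc2)C(=O)c2ccc(Br)cc2)ccc1F`, is not yet measured. It differs from compound 3 in one place: 4-fluoro-3-methoxyphenyl in place of 2-amino-3,5-dibromophenyl on a double-bonded chain carbon bound to a double-bonded chain carbon. This change undoes the kind of step that carried the other compounds up to the limit. The two steps that bear on it are an at least 100-fold higher number from compound 1 to compound 3 (2.00 log units; beyond the scatter) and an at least 100-fold higher number from compound 2 to compound 3 (2.00 log units; beyond the scatter); both are large and both run in the same direction, and compound 4 shares the methoxy-bearing ring pattern of compound 2. The expected step is therefore large and downward, an at least 66-fold lower number from compound 3 to compound 4 (1.82 log units; beyond the scatter). Its true size is hidden, though: compound 3 gives > 100000 nM, a limit of the assay. Compound 4 is estimated at 1500 nM, with a range from 300 nM to 10000 nM.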

Compound 4, concentration for 50% growth inhibition: 10000 nM
For compound 4 the middle estimate is 6.7-fold (0.82 log units) below the measured one; low and high end bracket the measured number.
By their numbers in this assay, from the lowest: compounds 1 and 2 (each within the scatter of the next); then compound 4. At a limit, above all of these: compound 3.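

In this assay, the ring on the double-bonded chain carbon proves sensitive to one small swap: fluoro in place of hydroxy on an aromatic carbon gives a 10-fold higher number from compound 2 to compound 4 (1.00 log units; beyond the scatter). The earlier compounds shown here showed only whole-ring changes, and here 4-fluoro-3-methoxyphenyl falls short of 2,4-dichlorophenyl, with a 10-fold higher number from compound 1 to compound 4 (1.00 log units; beyond the scatter), yet it sits well clear of 2-amino-3,5-dibromophenyl, with an at least 10-fold lower number from compound 3 to compound 4 (1.00 log units; beyond the scatter). Compound 3 holds a limit of the assay, so that last step gives only a bound: the limit of > 100000 nM in this assay, at which 1 of the 4 values shown sits.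

The compounds shown leave open whether an amine or a carboxylic acid in place of the hydroxy would keep the activity of compound 2 or lose it as the fluoro does. As far as these compounds go, it also stays open whether the amino group or the bromines of 2-amino-3,5-dibromophenyl matter more: here they appear only together.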